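The source may report more compounds than this note shows. Statements on the series, on what has been measured and on what is new or still open speak of the compounds shown alone.

In an assay on HEK293 cells for inhibition of Steryl-sulfatase (Homo sapiens), tested at 0.1 uM (a lower number here means a weaker effect, a higher number a stronger effect of the compound at the concentration tested), compound 2 `CCN(Cc1ccc(Br)cc1)c1cccc(C(=O)N2CCc3ccc(OS(N)(=O)=O)cc3C2)c1` gives 24.2%, which is the top number among the three measured, though both gaps to the other two fall within the scatter. Compound 1 `CCN(Cc1ccccc1)c1cccc(C(=O)N2CCc3ccc(OS(N)(=O)=O)cc3C2)c1` gives 17.3% in this assay, and compound 3 `NS(=O)(=O)Oc1ccc2c(c1)CN(C(=O)c1ccc(N3CCN(Cc4ccccc4)CC3)cc1)CC2` gives 20.8%. Within the data shown here, the only step between two compounds that differ in one place is a number 6.9 percentage points higher from compound 1 to compound 2 (within the scatter), bromo in place of hydrogen on an aromatic carbon, and it stays within the scatter.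

Compound 4 `CCN(Cc1ccncc1)c1cccc(C(=O)N2CCc3ccc(OS(N)(=O)=O)cc3C2)c1` has not yet been measured in this assay. It differs from compound 2 in one place: pyridin-4-yl in place of 4-bromophenyl on a saturated chain carbon bound to a nitrogen on an aromatic ring. Among the measured compounds shown here, no measured step covers this exchange directly. For the measured compounds named here, the step that bears on it most closely is a number 6.9 percentage points higher from compound 1 to compound 2 (within the scatter), which concerns the bromine alone and was within the scatter, so the loss of the bromine is not expected to move the number beyond the scatter; the hetero atom of the entering pyridin-4-yl ring has no counterpart among the measured compounds, and nothing in the data speaks for a large shift in either direction. Compound 4 is therefore expected to give 15% in this assay, with a range from 5% to 28%. This estimate means a step of a number 9.2 percentage points lower from compound 2 to compound 4 (within the scatter), which is expected to remain within the scatter.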

Compound 4, a percentage reported as inhibition, at one concentration (the size of the read-out at that concentration, not a potency): 33.3%
Compound 4: the middle estimate sits 18.3 percentage points below what was measured; measured number outside the range, above it.
By their numbers in this assay, from the lowest: compounds 1, 3, 2 and 4 (each within the scatter of the next, the first and the last beyond it).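

At this position, on a saturated chain carbon bound to a nitrogen on an aromatic ring, this assay gives its first step beyond the scatter among the compounds that differ in one place: a number 16 percentage points higher from compound 1 to compound 4 (beyond the scatter), with pyridin-4-yl in place of phenyl. Against the bromine-bearing ring the same exchange gives a number 9.1 percentage points higher from compound 2 to compound 4 (within the scatter), so a six-membered aromatic ring with a hetero atom is accepted here without any loss relative to 4-bromophenyl, and only the comparison with unsubstituted phenyl separates the numbers. Nothing available accounts for the gain over phenyl or assigns it to the ring nitrogen.

From the compounds shown here alone, it remains open whether other rings with hetero atoms, such as a pyrimidine or an imidazole, would hold or extend this number, and whether a propyl chain in place of the ethyl on the same nitrogen would change it. All of these figures are read-outs at one concentration, so they show only how strong or weak the effect is at that concentration.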